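The source may report more compounds than this note shows. Statements on the series, on what has been measured and on what is new or still open speak of the compounds shown alone.

Measured so far:
- Compound 1 `COC(=O)/C=C/c1cccc(N(Cc2ccc(/C=C/c3c(F)cccc3F)cc2)C(=O)C(C)C)c1`: 108 nM
- Compound 2 `COC(=O)/C=C/c1cccc(N(Cc2ccc(-c3ccc(OC(F)(F)F)cc3)cc2)C(=O)C(C)C)c1`: 219 nM

Among the compounds with values here, in an assay on isolated protein with Bile acid receptor (Homo sapiens) as the target (a higher number here means that more compound is needed for the effect, a lower number that less compound is needed), compound 2 stands with the highest of the two numbers; the only other compound, compound 1, sits at a lower value, and the gap between them is a 2.0-fold higher number from compound 1 to compound 2 (0.31 log units; beyond the scatter). Compound 3 `COC(=O)/C=C/c1cccc(N(Cc2ccc(/C=C/c3ccccc3)cc2)C(=O)C(C)C)c1` has not yet been measured. It differs from compound 2 in one place: 2-phenylethenyl in place of 4-(trifluoromethoxy)phenyl on an aromatic carbon. Within the data shown here, the one measured step that bears on this is a 2.0-fold higher number from compound 1 to compound 2 (0.31 log units; beyond the scatter), which exchanged a group at the same position and raised the number modestly. Compound 3 brings back an ethenyl-linked phenyl, much like compound 1 save for the fluorines of the 2-(2,6-difluorophenyl)ethenyl group, so a modest reversal is expected, around a 1.8-fold lower number from compound 2 to compound 3 (0.26 log units; within the scatter). Compound 3 is therefore estimated at 120 nM, with a range from 50 nM to 300 nM.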

Compound 3, half-maximal effective concentration: 65 nM
Compound 3: middle estimate off by 1.8-fold (0.27 log units), on the high side, and the stated range covers the measured number.
By their numbers in this assay, from the lowest: compounds 3 and 1 (each within the scatter of the next); then compound 2.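

In this assay, replacing 4-(trifluoromethoxy)phenyl with 2-phenylethenyl gives a 3.4-fold lower number from compound 2 to compound 3 (0.53 log units; beyond the scatter), so both compounds with an ethenyl-linked ring now have lower numbers than compound 2, whose ring is attached directly. Removing the two fluorines from the 2,6-difluorophenyl ring gives a 1.7-fold lower number from compound 1 to compound 3 (0.22 log units; within the scatter), so this change cannot be told apart from ordinary assay variation. No supporting data are available to explain either step.

Compound 2 and compound 3 differ both in the ethenyl link and in the trifluoromethoxy group, so the step cannot be assigned to either feature alone; a 2-[4-(trifluoromethoxy)phenyl]ethenyl group would separate the two. From the compounds shown here alone, how an amine or a carboxylic acid on the outer ring would behave also remains open.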